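The source may hold more compounds than are shown below. What is called first, only, known or untested is meant among the compounds shown, and "the series" means these compounds.

Compound 1, `Cc1c(Cc2ccccc2)c(=O)oc2cc(OCC(O)CNCCCCCCO)ccc12`, and compound 2, `Cc1cc(F)ccc1Cc1c(C)c2ccc(OCC(O)CN3CCC(C(N)=O)CC3)cc2oc1=O`, were both examined in an ADME assay on A549 cells (Homo sapiens) for cytotoxicity, read by CellTiter-Glo; on this read-out higher numbers stand for lower toxicity in this test and lower numbers for higher toxicity in this test. In this assay compound 1 gives 40300 nM. For compound 2 this assay reports no number but only a limit, > 100000 nM, so where compound 2 stands is known only as a bound at the top of the scale; this is the limit of > 100000 nM in this assay, at which 1 of the 2 values shown sits. Compound 1 and compound 2 differ in more than one place, so their two values say no more than that compound 1 reaches a measured number while compound 2 does not.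

Compound 3, `Cc1c(Cc2cccc3ccccc23)c(=O)oc2cc(OCC(O)CN3CCC(C(N)=O)CC3)ccc12`, has not been measured. It differs from compound 2 by naphthalen-1-yl in place of 4-fluoro-2-methylphenyl on a saturated chain carbon bound to an aromatic carbon. Within the data shown here, no measured pair shows what such an exchange does in this assay, so the expectation rests on the measured compounds alone. A step of an at least 1.2-fold lower number from compound 2 to compound 3 (0.09 log units; that floor lies within the scatter) is expected, that is, no movement beyond the usual scatter from the bound where compound 2 sits. Compound 3 is therefore expected to give about 80000 nM in this assay, with a likely range from 30000 nM to 200000 nM, and a fair chance that only a limit is reported again.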

Compound 3, half-maximal cytotoxic concentration: 42400 nM
Compound 3: middle estimate off by 1.9-fold (0.28 log units), on the high side, within the range that was stated.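

In this assay, the exchange of 4-fluoro-2-methylphenyl for naphthalen-1-yl on a saturated chain carbon bound to an aromatic carbon gives an at least 2.3-fold lower number from compound 2 to compound 3 (0.37 log units; beyond the scatter). This is the first change in a single place among the compounds shown, and it shows that the group held at this position can by itself move the read-out, from a limit at the top of the scale to a measured number, which on this read-out stands for higher toxicity in this test. The step gives only a minimum size, and how much larger it may be cannot be told, as the starting point is a limit and not a number: the limit of > 100000 nM in this assay, at which 1 of the 3 values shown sits.

The exchange adds a second six-membered aromatic ring and removes the fluorine and the methyl together, so the compounds shown leave open which of these parts goes with the lower number. They also leave open whether the step would hold for other groups at this place, such as naphthalen-2-yl, 4-fluorophenyl or quinolin-8-yl, or with the 4-fluoro-2-methylphenyl group kept and the amine side chain changed.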